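The source may hold more compounds than are shown below. What is called first, only, known or untested is meant among the compounds shown, and "the series" means these compounds.

Compound 1 (`COc1ccc(CNC(=O)c2c(C)nc3cc(C)ccn23)cc1`): > 128000 nM
Compound 2 (`COc1cccc(CNC(=O)c2c(C)nc3cc(C)ccn23)c1`): > 128000 nM
Compound 3 (`COc1ccccc1CNC(=O)c1c(C)nc2cc(C)ccn12`): > 128000 nM

All three compounds were tested in an ADME assay on Vero cells (Chlorocebus sabaeus) for cytotoxicity, with a stated time of 72 h (on this read-out lower numbers stand for stronger inhibition and higher numbers for weaker inhibition), and all carry a methoxy group on the same shared core. Each entry above is a limit of the assay and not a number. Compound 2, the starting point here, stands at > 128000 nM and that is a limit only. Taken together, the set shows the limit of > 128000 nM in this assay, at which 3 of the 3 values shown sit, and so offers no exact number to compare.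

Next comes compound 4 (`Cc1ccn2c(C(=O)NCc3cccc(F)c3)c(C)nc2c1`), which has not yet been measured. Compared with compound 2, it has fluoro in place of methoxy on an aromatic carbon, meta to a large group (fluoro in place of methoxy on an aromatic carbon). For the measured compounds named here, no measured pair here shows what this swap does, so the expectation has to stay cautious. It rests on compound 2 with its limit of > 128000 nM in this test. The step expected is a number no higher from compound 2 to compound 4 (the limit leaves the size open) and this means no change beyond the scatter, in either direction. Compound 4 is expected at 128000 nM in this assay with an estimated range from 50000 nM to 200000 nM and the test may well report only a limit again.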

Compound 4, half-maximal inhibitory concentration: > 128000 nM
Compound 4 gave a limit, no number (the forecaster's own chance of this, stated with the estimate: 80%); the middle value sits exactly at the limit.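

The step from compound 2 to compound 4, fluoro in place of methoxy, cannot be read, as both results in this assay are limits and not numbers. The compounds shown leave open how any one of them compares with another and at what concentration each would inhibit, as all share one result: the limit of > 128000 nM in this assay, at which 4 of the 4 values shown sit.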